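A Benzothiophene Variant Set Beside Its Pyridine Relatives

The source may report more compounds than this note shows. Statements on the series, on what has been measured and on what is new or still open speak of the compounds shown alone.

Of the compounds shown here, three sharing one core have been measured in a functional assay on Jurkat cells for inhibition of nuclear factor NF-kappa-B complex (Homo sapiens); on this read-out lower numbers stand for stronger inhibition and higher numbers for weaker inhibition. Compound 1 `CCOC(=O)c1cnc(-c2ccncc2)nc1NN1C(=O)C=C(C)C1=O` gives 6000 nM. Compound 2 `CCOC(=O)c1cnc(-c2cc(Cl)nc(Cl)c2)nc1NN1C(=O)C=C(C)C1=O` gives 2000 nM, the lowest of the three numbers, and compound 3 `CCOC(=O)c1cnc(-c2csc(C)n2)nc1NN1C(=O)C=C(C)C1=O` gives 8000 nM. The steps among them are modest: a 3.0-fold lower number from compound 1 to compound 2 (0.48 log units; beyond the scatter), a 1.3-fold higher number from compound 1 to compound 3 (0.12 log units; within the scatter) and a 4.0-fold higher number from compound 2 to compound 3 (0.60 log units; beyond the scatter). Compound 4 `CCOC(=O)c1cnc(-c2cc3ccccc3s2)nc1NN1C(=O)C=C(C)C1=O` has not yet been measured; it differs from compound 2 by 1-benzothiophen-2-yl in place of 2,6-dichloropyridin-4-yl on an aromatic carbon, at the place between two ring nitrogen atoms. For the measured compounds named here, no measured step brings in this group, so the steps to compound 1 and compound 3 bear only loosely on it; what they show is that exchanges at this place move the number by modest amounts in either direction. Compound 2 stands lowest at 2000 nM, so a modest step back toward the others is expected, namely a 2.0-fold higher number from compound 2 to compound 4 (0.30 log units; within the scatter). Compound 4 is accordingly estimated at 4000 nM, with a range from 1000 nM to 15000 nM.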

Compound 4, half-maximal inhibitory concentration: 4000 nM
The estimate for compound 4 equals the measured number at the digits printed; the range from low to high includes it.
By their numbers in this assay, from the lowest: compounds 2, 4, 1 and 3 (each within the scatter of the next, the first and the last beyond it).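

Set at the place between two ring nitrogen atoms, 1-benzothiophen-2-yl, with its five-membered aromatic ring and its six-membered aromatic ring of carbon only, gives a number that cannot be separated from any of the other three in this assay: a 2.0-fold higher number from compound 2 to compound 4 (0.30 log units; within the scatter), a 2.0-fold lower number from compound 3 to compound 4 (0.30 log units; within the scatter) and a 1.5-fold lower number from compound 1 to compound 4 (0.18 log units; within the scatter). Compound 4 thus lies within the scatter of both compound 2 and compound 3, even though those two lie beyond the scatter of each other. Nothing available gives a reason for these numbers.

From the compounds shown here alone, whether an amine or a carboxylic acid on the 1-benzothiophen-2-yl group would shift the number remains open. So does the effect of replacing the ethoxycarbonyl group with an amide or a carboxylic acid while this group stays in place.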